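Cyano for methyl on the pyridine flank of compound 3

The source may hold more compounds than are shown below. What is called first, only, known or untested is meant among the compounds shown, and "the series" means these compounds.

All three measured compounds share one core and differ only in the group para on the anilide ring. In a functional assay for antagonist activity at transient receptor potential cation channel subfamily V member 1 (Rattus norvegicus) (a lower number here means a stronger inhibitor, a higher number a weaker inhibitor), compound 1 `Cc1cccnc1-c1ccc(C(=O)Nc2ccc(Cl)cc2)cc1` gives 2020 nM; compound 2 `Cc1cccnc1-c1ccc(C(=O)Nc2ccc(C(F)(F)F)cc2)cc1` gives 81 nM; compound 3 `Cc1cccnc1-c1ccc(C(=O)Nc2ccc(C(C)(C)C)cc2)cc1` gives 9 nM. The steps are a 25-fold lower number from compound 1 to compound 2 (1.40 log units; beyond the scatter), a 220-fold lower number from compound 1 to compound 3 (2.35 log units; beyond the scatter) and a 9.0-fold lower number from compound 2 to compound 3 (0.95 log units; beyond the scatter). Compound 3 therefore stands lowest of the three numbers in this assay, beyond the scatter from both others.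

Compound 4 `CC(C)(C)c1ccc(NC(=O)c2ccc(-c3ncccc3C#N)cc2)cc1` keeps the tert-butyl anilide of compound 3 and differs by cyano in place of methyl on an aromatic carbon; cut one bond further out, the change reads 3-methylpyridin-2-yl to 3-cyanopyridin-2-yl. Among the measured compounds shown here, no measured step touches this position: the three steps recorded all sit on the anilide side, so nothing here tells how the ring with 1 nitrogen tolerates a substituent swap. For the measured compounds named here, with no bearing step, the working expectation is a step within or near the scatter rather than a large one. Compound 4 is estimated at 15 nM, with a range from 4 nM to 60 nM. The expected step is a 1.7-fold higher number from compound 3 to compound 4 (0.22 log units; within the scatter), given as an expectation only.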

Compound 4, half-maximal inhibitory concentration: 13 nM
The estimate for compound 4 lay 1.2-fold (0.06 log units) above the measured number; measured number inside the range.
By their numbers in this assay, from the lowest: compounds 3 and 4 (each within the scatter of the next); then compound 2; then compound 1.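

In this assay, replacing 3-methylpyridin-2-yl with 3-cyanopyridin-2-yl gives a 1.4-fold higher number from compound 3 to compound 4 (0.16 log units; within the scatter), so with the tert-butyl anilide held fixed, this position ortho to a large group accepts cyano without a step beyond the scatter. Among the compounds shown here, the earlier steps all sit on the anilide side, where a 220-fold lower number from compound 1 to compound 3 (2.35 log units; beyond the scatter) is large, whereas this step, with 2 heavy atoms and 1 hydrogen-bond acceptor entering for 1 heavy atom and no acceptor, gives the first reading on the other flank. No measurement shown gives a reason for this result.

A single pair does not show whether cyano is equally tolerated with the chloro or trifluoromethyl anilides of compound 1 and compound 2. From the compounds shown here alone, how this position responds to an amine, a carboxylic acid or a longer chain also remains open.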